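A few compounds are considered here, and "the series" means these few. Any claim that something is new, unique, unknown or untested is made for them only; others in the source may bear on it.

Measured so far:
compound 1, `Clc1cccc(-c2nnnn2Cc2ccccn2)c1Cl`, 501 nM
compound 2, `Cc1ncccc1Cn1nnnc1-c1cccc(Cl)c1Cl`, 31.6 nM

Both numbers come from an in vitro functional assay on 1321-N1 cells for antagonist activity at P2X purinoceptor 7 (Homo sapiens), read by FLIPR and calcium flux; a higher number here means a weaker inhibitor, a lower number a stronger inhibitor. Compound 2 stands at the lowest of the two numbers; its nearest neighbour is compound 1, reached by a 16-fold lower number from compound 1 to compound 2 (1.20 log units; beyond the scatter).

Compound 3, `Cc1nc(C)c(Cn2nnnc2-c2cccc(Cl)c2Cl)s1`, has not been measured. It differs from compound 2 by 2,4-dimethyl-1,3-thiazol-5-yl in place of 2-methylpyridin-3-yl on a saturated chain carbon bound to an aromatic nitrogen. Going by the values given here, no measured step bears on this change: the only step on record, a 16-fold lower number from compound 1 to compound 2 (1.20 log units; beyond the scatter), concerns a different exchange at the same place, and it shows only that this position can move the number strongly. Without a matching precedent, a step of no more than the usual scatter is expected, perhaps a slight loss. For compound 3 in this assay the expected value is 45 nM, range 15 nM to 150 nM, which means an expected step of a 1.4-fold higher number from compound 2 to compound 3 (0.15 log units; within the scatter).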

Compound 3, half-maximal inhibitory concentration: 50.1 nM
The estimate for compound 3 lay 1.1-fold (0.05 log units) below the measured number; the range from low to high includes it.
By their numbers in this assay, from the lowest: compounds 2 and 3 (each within the scatter of the next); then compound 1.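

In this assay, 2,4-dimethyl-1,3-thiazol-5-yl replaces 2-methylpyridin-3-yl with a 1.6-fold higher number from compound 2 to compound 3 (0.20 log units; within the scatter) and so shows that this position takes a five-membered aromatic ring with 2 hetero atoms as well as a six-membered one. Set against pyridin-2-yl, the same group gives a 10-fold lower number from compound 1 to compound 3 (1.00 log units; beyond the scatter) and so shows that the large gap seen with compound 2 is not confined to pyridine rings. No measurement on hand explains this. The compounds shown leave open whether the methyl groups account for that gap. Also open, from the compounds shown here alone, is how an amine, a carboxylic acid or a longer chain would read at this position.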